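Removing the Whole Side Group from Compound 1

This account rests on a few compounds, and the source may have more. Where it says the series, first, only, none or still open, it means among the compounds named here.

Compound 1 `Cc1ccc(S(=O)(=O)NCc2cn(C[C@H](O)[C@H]3OC(=O)C(OCc4ccccc4)=C3OCc3ccccc3)nn2)cc1` was tested in a functional assay on HeLa cells (Homo sapiens) for antiproliferative activity, read by MTT assay, with a stated time of 72 h (a higher number here means a weaker inhibitor, a lower number a stronger inhibitor), where compound 1 gives 14400 nM. Of the two compounds with a number, compound 1 has the lower one; the nearest is compound 2 `O=C1O[C@H]([C@@H](O)Cn2cc(-c3cc(F)cc(F)c3)nn2)C(OCc2ccccc2)=C1OCc1ccccc1`, which in this assay gives 40800 nM. Compound 3 `CCCCCc1ccc(-c2cn(C/C=C3\OC(=O)C(OCc4ccccc4)=C3OCc3ccccc3)nn2)cc1` gives only > 100000 nM in this assay, which is a limit of the assay and not a number.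

Compound 4 `O=C1O[C@H]([C@@H](O)Cn2ccnn2)C(OCc2ccccc2)=C1OCc1ccccc1` differs from compound 1 in one place: hydrogen in place of (((4-methylphenyl)sulfonyl)amino)methyl on an aromatic carbon. Within the data shown here, the single measured step that touches this position is a 2.8-fold higher number from compound 1 to compound 2 (0.45 log units; beyond the scatter), where one large group on the five-membered aromatic ring with three nitrogens was swapped for another and the number rose modestly. Compound 4 carries no group there at all, a more drastic change than that swap, so the expectation is a somewhat weaker inhibitor, a 2.8-fold higher number from compound 1 to compound 4 (0.44 log units; beyond the scatter). The estimate for compound 4 in this assay is 40000 nM, expected to fall between 12000 nM and 130000 nM.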

Compound 4, half-maximal inhibitory concentration: > 100000 nM
Compound 4 was reported as a limit; the forecaster's own chance of this, stated with the estimate: 30%; middle value at least 2.5-fold (0.39 log units) from the limit.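

In this assay compound 4 gives > 100000 nM, which is a limit of the assay and not a number. With hydrogen on this aromatic carbon, the result is an at least 6.9-fold higher number from compound 1 to compound 4 (0.84 log units; beyond the scatter) and an at least 2.4-fold higher number from compound 2 to compound 4 (0.38 log units; beyond the scatter), so both large groups give a lower number than hydrogen, something the earlier swap of one large group for another could not show. Each of these steps is a minimum and not an exact size: the limit of > 100000 nM in this assay, at which 2 of the 4 values shown sit.

The compounds shown leave open which part of the side group of compound 1 matters most: the sulfonyl, the 4-methylphenyl ring or the carbon link to the ring with three nitrogens. A small group on this carbon, such as a methyl or an aminomethyl, would show how much of a side group is needed to bring the number down from that limit.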